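Replacing phenethyl with 4-methoxyphenoxy on a shared quinoline-free core

The source may report more compounds than this note shows. Statements on the series, on what has been measured and on what is new or still open speak of the compounds shown alone.

This account follows one step in an ADME assay for permeability, using PAMPA, with a stated time of 30 min, at pH 7.4 (a higher number here means that the compound crosses the layer faster, a lower number that the compound crosses the layer more slowly), starting from compound 2 `c1ccc(CCc2ccc3c(NCCCNCc4ccco4)ccnc3c2)cc1`, which gives 23 10^-6 cm/s. Among the three measured compounds, compound 2 stands lowest: compound 1 `COc1ccc(-c2ccc3c(NCCCNCc4cccc(OC)c4O)ccnc3c2)cc1` gives 237 10^-6 cm/s, and compound 3 `COc1cccc(CNCCCNc2ccnc3cc(-c4ccc(C(C)(C)C)cc4)ccc23)c1O` gives 237 10^-6 cm/s, each a step beyond the scatter above compound 2. For the measured compounds named here, the only single-point step measured so far is no change at the digits printed from compound 1 to compound 3 (within the scatter), which concerns a different part of the core and does not bear directly on the change considered here.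

Compound 4 `COc1ccc(Oc2ccc3c(NCCCNCc4ccco4)ccnc3c2)cc1` is not yet measured in this assay. It differs from compound 2 as follows: 4-methoxyphenoxy in place of phenethyl on an aromatic carbon. Going by the values given here, no measured pair shares this particular change, so the expectation rests on what the values of compound 1 and compound 2 show. Compound 1, which carries a related methoxy-bearing aromatic group at the same place, gives 237 10^-6 cm/s, while compound 2 gives 23 10^-6 cm/s; the two also differ in their side chains, so the comparison is indirect. On that basis compound 4 is expected to move upward from compound 2 by a 2.6-fold higher number from compound 2 to compound 4 (0.42 log units; beyond the scatter), a step that may or may not exceed the scatter. The estimate for compound 4 is 60 10^-6 cm/s, with a range from 20 10^-6 cm/s to 180 10^-6 cm/s.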

Compound 4, apparent permeability: 317 10^-6 cm/s
Estimate against measurement, compound 4: 5.3-fold (0.72 log units) below; the measured number lies above the stated range.
By their numbers in this assay, from the lowest: compound 2; then compounds 1, 3 and 4 (each within the scatter of the next).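

In this assay, the aromatic carbon that carries phenethyl in compound 2 proves sensitive to the group placed there, with the rest of the molecule unchanged: a 14-fold higher number from compound 2 to compound 4 (1.14 log units; beyond the scatter). The only earlier step of a single change, no change at the digits printed from compound 1 to compound 3 (within the scatter), gave no sign of such a large shift, so this is the first evidence among these compounds that one substitution can move the number beyond the scatter. The exchange replaces a group with no hydrogen-bond acceptors by one with two and adds one heavy atom, while both groups hold one six-membered aromatic ring, but no measurement here shows what produces the step.

The compounds shown leave open whether the step goes with the oxygen joining the ring to the core, with the methoxy group, or with both, and an unsubstituted phenoxy or a 4-aminophenoxy group at this carbon would separate these readings. They also leave open whether the same exchange would give a similar step on the side chain of compound 1.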